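Hydroxy removal on the rearranged core, second instance

This account rests on a few compounds, and the source may have more. Where it says the series, first, only, none or still open, it means among the compounds named here.

Compound 1 `COc1ccc(-c2cccc(=O)n2-c2cc(OC)c(OC)c(OC)c2)cc1O` and compound 2 `COc1ccc(-c2cccc(=O)n2-c2cc(OC)c(OC)c(OC)c2)cc1` share one core; compound 3 `COc1ccc(-n2c(-c3cc(OC)c(OC)c(OC)c3)cccc2=O)cc1O` holds the same atoms joined differently, and the difference between the two cores is not broken down here. In a functional assay on HepG2 cells (Homo sapiens) for cytotoxicity, read by spectrophotometry, with a stated time of 72 h (on this read-out higher numbers stand for weaker inhibition and lower numbers for stronger inhibition), compound 1 gives < 10 nM, which is a limit of the assay. Compound 2 likewise gives < 10 nM in this assay, also a limit. The change hydrogen in place of hydroxy on an aromatic carbon thus yields a step that the two limits leave unreadable from compound 1 to compound 2, owing to the limit of < 10 nM in this assay, at which 2 of the 3 values shown sit. Going by the values given here, compound 3 gives 1220 nM in this assay, the only plain number in the set. Compound 4 `COc1ccc(-n2c(-c3cc(OC)c(OC)c(OC)c3)cccc2=O)cc1` differs from compound 3 by hydrogen in place of hydroxy on an aromatic carbon, the same change at the same place. With the measured instance unreadable, the step from compound 3 is expected to be modest, a 1.6-fold higher number from compound 3 to compound 4 (0.21 log units; within the scatter). Compound 4 is accordingly estimated near 2000 nM.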

Compound 4, half-maximal inhibitory concentration: 5740 nM
Beside the measured number, compound 4's estimate is 2.9-fold (0.46 log units) below it; the measured number falls inside the stated range.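

In this assay, hydrogen in place of hydroxy gives a 4.7-fold higher number from compound 3 to compound 4 (0.67 log units; beyond the scatter), so on this core the 3-hydroxy-4-methoxyphenyl group carries the stronger inhibition and 4-methoxyphenyl the weaker. The same change on the core of compound 1 cannot be read, because compound 1 and compound 2 both sit at a limit: the limit of < 10 nM in this assay, at which 2 of the 4 values shown sit.

Going by these compounds alone, only one readable instance therefore stands, and it does not show whether the size of the step carries from one core to the other. The compounds shown leave open how an amine or a carboxylic acid in place of the hydroxy would read on either core. Also open, from the compounds shown here alone, is the size of the hydroxy change on the core of compound 1, where no plain number stands.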